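Sulfanyl to Sulfonyl Bridge in Hydroxyphenyl Anilides

The compounds below may be only part of what the source reports. "The series", "measured", "known", "first", "only" and "open" are said of these compounds alone.

Measured so far:
compound 1, `O=C(Nc1ccc([N+](=O)[O-])c(C(F)(F)F)c1)c1ccc(Sc2ccc(O)cc2)cc1`: 3580 nM
compound 2, `O=C(Nc1ccc(S(F)(F)(F)(F)F)cc1)c1ccc(Sc2ccc(O)cc2)cc1`: 4860 nM
compound 3, `O=C(Nc1ccc([N+](=O)[O-])c(C(F)(F)F)c1)c1ccc(S(=O)(=O)c2ccc(O)cc2)cc1`: 4960 nM

All three were run in a functional assay on LNCaP cells (Homo sapiens) for antiproliferative activity, read by fluorescence and propidium iodide staining, with a stated time of 96 h; on this read-out higher numbers stand for weaker inhibition and lower numbers for stronger inhibition. Compound 1 gives 3580 nM and compound 3 gives 4960 nM. The structural difference between them is (4-hydroxyphenyl)sulfonyl in place of (4-hydroxyphenyl)sulfanyl on an aromatic carbon, and the resulting step is a 1.4-fold higher number from compound 1 to compound 3 (0.14 log units; within the scatter). Compound 2 gives 4860 nM. The difference between the cores of compound 1 and compound 2 is not broken down here; their two values lie within the scatter of each other, so nothing is read from the comparison.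

Compound 4 , `O=C(Nc1ccc(S(F)(F)(F)(F)F)cc1)c1ccc(S(=O)(=O)c2ccc(O)cc2)cc1`, has not been measured in this assay. It differs from compound 2 by (4-hydroxyphenyl)sulfonyl in place of (4-hydroxyphenyl)sulfanyl on an aromatic carbon. For the measured compounds named here, this is the same change as from compound 1 to compound 3, at a place described in the same words, so the one measured step is the only guide. For compound 4 the expected step is a 1.3-fold higher number from compound 2 to compound 4 (0.11 log units; within the scatter), because the same change gave a 1.4-fold higher number from compound 1 to compound 3 (0.14 log units; within the scatter). Compound 4 is therefore estimated at 6200 nM in this assay, with a range from 3400 nM to 11500 nM.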

Compound 4, half-maximal inhibitory concentration: 2490 nM
For compound 4 the middle estimate is 2.5-fold (0.40 log units) above the measured one, and the stated range ends above it.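

In this assay, placing (4-hydroxyphenyl)sulfonyl where (4-hydroxyphenyl)sulfanyl stood gives a 2.0-fold lower number from compound 2 to compound 4 (0.29 log units; within the scatter), and taken alone this step stays within the scatter. Set beside the earlier step, however, it shows that the change does not carry over from one core to the other as a fixed increment: the same change on two cores in this assay, a 1.4-fold higher number (0.14 log units; within the scatter) from compound 1 to compound 3 and a 2.0-fold lower number (0.29 log units; within the scatter) from compound 2 to compound 4, 2.7-fold (0.43 log units) apart, beyond the scatter of two such steps. This shows only that the outcome of the change differs between these two cores; with one pair per core, it gives neither the direction of the change on a further core nor the structural reason for the gap.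

The compounds shown leave open whether a third core, such as an anilide carrying a nitrile or a chlorine in place of the groups seen here, would follow either step. Also open, as far as these compounds go, is how the same comparison would run with a sulfinyl or ether bridge, or with a methoxy group or an amine in place of the hydroxyl.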